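Methoxy in Place of Chloro on a Urea: Solubility Outlook

This account rests on a few compounds, and the source may have more. Where it says the series, first, only, none or still open, it means among the compounds named here.

Measured compounds:
compound 1 `COc1cccc(NC(=O)Nc2cc(C)nc3ccccc23)c1` gives 1200 nM in a physicochemical assay for solubility, at pH 7.4; a lower number here means a less soluble compound, a higher number a more soluble compound;
compound 2 `Cc1cc(NC(=O)Nc2ccc(Cl)cc2)c2ccccc2n1` gives 1400 nM in this assay;
compound 3 `Cc1cc(NC(=O)Nc2cccc(Cl)c2)c2ccccc2n1` gives 800 nM in this assay.

Compound 3 and compound 1 differ in one place, (methoxy in place of chloro on an aromatic carbon), and the step between them in this assay is a 1.5-fold higher number from compound 3 to compound 1 (0.18 log units; within the scatter). Compound 2 and compound 3 share the same atoms joined differently, the difference being (4-chlorophenyl in place of 3-chlorophenyl on an amide-type nitrogen); the step in this assay is a 1.8-fold lower number from compound 2 to compound 3 (0.24 log units; within the scatter).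

Compound 4 `COc1ccc(NC(=O)Nc2cc(C)nc3ccccc23)cc1` is the unmeasured compound. It differs from compound 2 by methoxy in place of chloro on an aromatic carbon. Going by the values given here, this is the same kind of change as the one from compound 3 to compound 1, though not the same: there the methoxy sits meta to a large group, here para to a large group. Beside the measured step of a 1.5-fold higher number from compound 3 to compound 1 (0.18 log units; within the scatter), the expected step in this assay from compound 2 to compound 4 is a 1.3-fold higher number from compound 2 to compound 4 (0.11 log units; within the scatter), resting on that single measured pair. For compound 4 in this assay the estimate is 1800 nM, between 900 nM and 3600 nM.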

Compound 4, solubility: 19800 nM
Beside the measured number, compound 4's estimate is 11-fold (1.04 log units) below it; measured number above the stated range.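

In this assay the change from chloro to methoxy, para to a large group, gives a 14-fold higher number from compound 2 to compound 4 (1.15 log units; beyond the scatter) and so stands well beyond the scatter, while the same kind of change at another place on the ring gives a 1.5-fold higher number from compound 3 to compound 1 (0.18 log units; within the scatter) and stays within it. Both pairs share one core, so the size of this change did not carry from one pair to the other even without a change of core, and where the group sits may matter; two pairs show this much, but they do not show a rule, and they say nothing about how the change would behave on a different core. Nothing shown here accounts for the large step.

Still open, as far as these compounds go, is whether the large step belongs to methoxy itself or would also appear with another group at that place, such as ethoxy, an amine or a carboxylic acid. Also open, from the compounds shown here alone, is whether compound 4 keeps its high number when the shared core is altered.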